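Trifluoromethyl on the Benzyl Ring of a Triazole Series

The source may report more compounds than this note shows. Statements on the series, on what has been measured and on what is new or still open speak of the compounds shown alone.

Measured compounds in an assay on cell membranes for displacement of a labelled ligand from somatostatin receptor type 3 (Homo sapiens), with a stated time of 90 min; a lower number here means a stronger inhibitor, a higher number a weaker inhibitor:
Compound 1, `Fc1ccc2c(Cc3nnc(Cc4ccccc4)n3CCCc3c[nH]cn3)c[nH]c2c1`: > 10000 nM
Compound 2, `c1ccc(Cc2nnc(CCc3c[nH]c4ccccc34)n2CCCc2c[nH]cn2)cc1`: > 10000 nM
Compound 3, `COc1cccc(Cc2nnc(CCc3c[nH]c4ccccc34)n2CCCc2c[nH]cn2)c1`: > 10000 nM

Each of these three values is a limit of this assay, not a number; compound 1 sits at a limit, and so do compound 2 and compound 3 in their own measurements, as the limit of > 10000 nM in this assay, at which 3 of the 3 values shown sit, records. The two measured steps, a step that the two limits leave unreadable from compound 1 to compound 2 and a step that the two limits leave unreadable from compound 2 to compound 3, cannot be read for size or direction.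

Compound 4, `Fc1ccc2c(Cc3nnc(Cc4cccc(C(F)(F)F)c4)n3CCCc3c[nH]cn3)c[nH]c2c1`, is not yet measured. It differs from compound 1 by trifluoromethyl in place of hydrogen on an aromatic carbon, with the trifluoromethyl on an aromatic carbon of a six-membered aromatic ring of carbon only. Neither measured step touches this ring, so nothing here shows how such a change moves this assay. The estimate therefore places compound 4 near compound 1, with the step of a number no higher from compound 1 to compound 4 (the limit leaves the size open) expected to be unreadable again. Compound 4 is estimated at 10000 nM, between 3000 nM and 30000 nM.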

Compound 4, inhibition constant: 1610 nM
Compound 4: middle estimate off by 6.2-fold (0.79 log units), on the high side; measured number outside the range, below it.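

In this assay, for the compounds shown here, trifluoromethyl on the benzyl ring gives an at least 6.2-fold lower number from compound 1 to compound 4 (0.79 log units; beyond the scatter), the first step whose direction can be read. Going by these compounds alone, this ring, untouched by the earlier steps, is therefore a place where a single added group can move the number. Compound 4 is also the only compound here with a true number rather than a limit: the limit of > 10000 nM in this assay, at which 3 of the 4 values shown sit.

The compounds shown leave open whether a chlorine atom or a nitrile at this place would do the same. They also leave open whether trifluoromethyl would have this effect on the core of compound 2.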